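The source may report more compounds than this note shows. Statements on the series, on what has been measured and on what is new or still open speak of the compounds shown alone.

Compound 1 `Cn1cc(NC(=O)c2ccncc2Nc2cc(-c3ccc4ccn(C)c4c3)c3nccnc3c2)cn1`: 0.2 h
Compound 2 `CN1CC(NC(=O)c2ccncc2Nc2cc(-c3ccc4ccn(C)c4c3)c3nccnc3c2)CCC1=O`: 0.75 h
Compound 3 `CC(=O)N1CCOC(CNC(=O)c2ccncc2Nc2cc(-c3ccc4ccn(C)c4c3)c3nccnc3c2)C1`: 0.217 h

In an ADME assay on microsomes from liver (Mus musculus, strain CD-1) for metabolic stability, read by LC-MS, tested at 2 uM (a lower number here means that the compound disappears faster, a higher number that the compound lasts longer), compound 3 stands within the scatter of compound 1, and both lie under compound 2, the highest of the three. Compound 4 `CN1CCC(N(C)C(=O)c2ccncc2Nc2cc(-c3ccc4ccn(C)c4c3)c3nccnc3c2)C1` differs from compound 3 in one place: methyl(1-methylpyrrolidin-3-yl)amino in place of ((4-acetylmorpholin-2-yl)methyl)amino on a carbonyl carbon. Going by the values given here, no measured compound carries methyl(1-methylpyrrolidin-3-yl)amino, so only the other swaps at this amide bear on it. These are a 1.1-fold higher number from compound 1 to compound 3 (0.04 log units; within the scatter), a 3.8-fold higher number from compound 1 to compound 2 (0.57 log units; beyond the scatter) and a 3.5-fold lower number from compound 2 to compound 3 (0.54 log units; beyond the scatter). Among the compounds with values here, they run in both directions and stay modest, so no large step and no firm direction can be expected in this assay. The expected step is a 1.4-fold higher number from compound 3 to compound 4 (0.14 log units; within the scatter). Compound 4 is estimated at 0.3 h, with an expected range from 0.11 h to 0.8 h.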

Compound 4, half-life: > 1 h
Compound 4 ended at the assay's limit; the forecaster's own chance of this, stated with the estimate: 5%; middle value at least 3.3-fold (0.52 log units) away from the limit.
By their numbers in this assay, from the lowest: compounds 1 and 3 (each within the scatter of the next); then compound 2. At a limit, above all of these: compound 4.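

In this assay compound 4 stands at a limit, not at a number: the limit of > 1 h in this assay, at which 1 of the 4 values shown sits. This place on the carbonyl carbon can therefore shift the half-life beyond the scatter, with an at least 4.6-fold higher number from compound 3 to compound 4 (0.66 log units; beyond the scatter) and an at least 5.0-fold higher number from compound 1 to compound 4 (0.69 log units; beyond the scatter). The floor against compound 2 is smaller: an at least 1.3-fold higher number from compound 2 to compound 4 (0.12 log units; that floor lies within the scatter), so compound 4 is not yet clearly separated from compound 2.

From the compounds shown here alone, how far compound 4 lies past its limit stays open. Also open, going by these compounds, is whether the methyl on the amide nitrogen or the five-membered ring matters more, which plain (1-methylpyrrolidin-3-yl)amino would test.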